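Two limits and one number in a weak series

The source may report more compounds than this note shows. Statements on the series, on what has been measured and on what is new or still open speak of the compounds shown alone.

Measured in a physicochemical assay, with a stated time of 6 min; a lower number here means a stronger inhibitor, a higher number a weaker inhibitor:
- Compound 1 `O=C(Nc1ccc(Br)cc1)Nc1nc(-c2cc3ccccc3o2)cs1`: > 200000 nM
- Compound 2 `Cc1ccc(NC(=O)Nc2nc(-c3cc4cc(Br)ccc4o3)cs2)cc1`: > 200000 nM
- Compound 3 `O=C(Nc1ccccc1)Nc1nc(-c2cc3cc([N+](=O)[O-])ccc3o2)cs1`: 183000 nM

Compound 2 stands at the limit of > 200000 nM in this assay, at which 2 of the 3 values shown sit. This is a limit and not a number, and the same is true of compound 1.

Compound 4 `O=C(Nc1cccc([N+](=O)[O-])c1)Nc1nc(-c2cc3cc(Br)ccc3o2)cs1` has not been measured yet. It differs from compound 2 in one place: 3-nitrophenyl in place of 4-methylphenyl on an amide-type nitrogen. For the measured compounds named here, no measured pair shows this change directly. A small step towards a lower number is expected in this assay because compound 3 gives 183000 nM and carries a nitro group of its own. The estimated change is an at least 1.8-fold lower number from compound 2 to compound 4 (0.25 log units; that floor lies within the scatter). For compound 4 the expected value is 110000 nM, with an estimated range from 40000 nM to 200000 nM.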

Compound 4, half-maximal inhibitory concentration: 159000 nM
The estimate for compound 4 lay 1.4-fold (0.16 log units) below the measured number; low and high end bracket the measured number.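

In this assay, for the compounds shown here, 3-nitrophenyl in place of 4-methylphenyl on the amide-type nitrogen gives the only step that can be read so far: an at least 1.2-fold lower number from compound 2 to compound 4 (0.09 log units; that floor lies within the scatter). That step is only a floor, since compound 2 has a limit and not a number: the limit of > 200000 nM in this assay, at which 2 of the 4 values shown sit. From the compounds shown here alone, compound 4 shows that this position can carry 3-nitrophenyl and still give a true number, but the real size of the change stays unknown.

The compounds shown leave open whether an amine or a carboxylic acid on this phenyl ring would give a step beyond the scatter.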